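This account rests on a few compounds, and the source may have more. Where it says the series, first, only, none or still open, it means among the compounds named here.

Compound 1 `O=C(CSc1nnnn1-c1ccccc1)N/N=c1/scc(-c2ccc(Br)cc2)n1-c1ccccc1` is examined in a functional assay on C6 cells (Rattus norvegicus) for cytotoxicity, read by MTT assay, with a stated time of 24 h, tested at 100 ug/mL (a lower number here means a stronger effect, a higher number a weaker effect of the compound at the concentration tested), where compound 1 gives 24.3%. Of the three numbers measured, compound 1 has the lowest, though compound 3 `Cc1nnc(SCC(=O)N/N=c2/scc(-c3ccc(Cl)cc3)n2-c2ccccc2)s1`, which gives 34.1%, lies within the scatter of it, while compound 2 `Cc1nnc(SCC(=O)N/N=c2/scc(-c3ccc(F)cc3)n2-c2ccccc2)s1`, which gives 34.9%, lies beyond it. Going by the values given here, the one measured step between neighbours, a number 0.8 percentage points lower from compound 2 to compound 3 (within the scatter), comes with chloro in place of fluoro on an aromatic carbon. Compound 4 `Cc1ccc(-c2cs/c(=N/NC(=O)CSc3nnnn3-c3ccccc3)n2-c2ccccc2)cc1` differs from compound 1 by methyl in place of bromo on an aromatic carbon. Among the compounds with values here, no measured step exchanges bromo for methyl, and the only exchange of a ring substituent measured, a number 0.8 percentage points lower from compound 2 to compound 3 (within the scatter), stayed within the scatter, so no step beyond the scatter is expected in this assay. Compound 4 is therefore expected to give 30%, between 18% and 42%, an expected step of a number 5.7 percentage points higher from compound 1 to compound 4 (within the scatter).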

Compound 4, a percentage reported as activity, at one concentration (the size of the read-out at that concentration, not a potency): 28.5%
Beside the measured number, compound 4's estimate is 1.5 percentage points above it; the measured number falls inside the stated range.
By their numbers in this assay, from the lowest: compounds 1, 4, 3 and 2 (each within the scatter of the next, the first and the last beyond it).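

Going from 4-bromophenyl to 4-methylphenyl in this assay gives a number 4.2 percentage points higher from compound 1 to compound 4 (within the scatter) and so shows that, at this place on the ring, a methyl and a bromo cannot be told apart. The earlier exchange swapped one halogen for another, whereas this one puts a carbon group in place of a halogen and still stays within the scatter. No evidence here bears on this result. On these data alone, whether an amine, a carboxylic acid or a longer chain at this place would also read alike stays open.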